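A few compounds are considered here, and "the series" means these few. Any claim that something is new, unique, unknown or untested is made for them only; others in the source may bear on it.

Measured in a functional assay on HCC827 cells (Homo sapiens) for inhibition, read by fluorescence, with a stated time of 72 h; on this read-out higher numbers stand for weaker inhibition of growth and lower numbers for stronger inhibition of growth:
- compound 1 `CC(C)=CCn1cnc2c(Nc3cccc(Cl)c3)nc(N[C@H]3CC[C@H](N)CC3)nc21`: 13500 nM
- compound 2 `CC(C)CCn1cnc2c(Nc3cccc(Cl)c3)nc(N[C@H]3CC[C@H](N)CC3)nc21`: 10300 nM

For the measured compounds named here, the one measured step is a 1.3-fold lower number from compound 1 to compound 2 (0.12 log units; within the scatter). Going by the values given here, on these numbers, compound 2 therefore cannot be ranked against the only other measured compound.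

Compound 3 `N[C@H]1CC[C@H](Nc2nc(Nc3cccc(Cl)c3)c3ncn(Cc4ccccc4)c3n2)CC1` follows from compound 2 by phenyl in place of isobutyl on a saturated chain carbon bound to an aromatic nitrogen. Cut one bond further out, the same difference reads isopentyl to benzyl.

The measured step bears on this change only in part. It falls at the same place, but it exchanges one open chain for another, and no group containing a ring has been measured there. The data therefore give no direction for the change, and no step beyond the scatter is expected in this assay, though with wide uncertainty.

The estimated change is a 1.1-fold lower number from compound 2 to compound 3 (0.06 log units; within the scatter). For compound 3 the expected value is 9000 nM, with an estimated range of 3500 nM to 22000 nM.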

Compound 3, concentration for 50% growth inhibition: 13700 nM
For compound 3 the middle estimate is 1.5-fold (0.18 log units) below the measured one; the range from low to high includes it.
By their numbers in this assay, from the lowest: compounds 2, 1 and 3 (each within the scatter of the next).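

In this assay, a group containing a ring now stands at this position, and phenyl in place of isobutyl gives a 1.3-fold higher number from compound 2 to compound 3 (0.12 log units; within the scatter), while phenyl in place of 2-methylprop-1-en-1-yl gives a 1.0-fold higher number from compound 1 to compound 3 (0.01 log units; within the scatter). On a saturated chain carbon bound to an aromatic nitrogen, the six-membered aromatic ring of carbon therefore cannot be told apart from either open chain on this read-out, and the three compounds cannot be ranked. Nothing at hand offers an explanation for this result.

The compounds shown leave open whether any group at this position can move the number in this assay beyond the scatter, for example a chain ending in an amine or a carboxylic acid, a longer chain, or a benzyl ring carrying a chlorine or a methoxy group. They also leave open whether the same exchanges would still give steps within the scatter with a different group in place of the 3-chlorophenyl amine on the shared core, or whether the position would then begin to separate compounds.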